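This account rests on a few compounds, and the source may have more. Where it says the series, first, only, none or still open, it means among the compounds named here.

Three compounds have been measured in a physicochemical assay for solubility, read by HPLC, in simulated intestinal fluid, with a stated time of 3 days, at pH 6.8; on this read-out higher numbers stand for higher solubility and lower numbers for lower solubility:

- compound 1, `Cn1cc(C(=O)Nc2ccc(-c3ccccc3)c(C(F)(F)F)c2)c(=O)c2cnccc21`: 5 ug/mL
- compound 2, `Cn1cc(C(=O)Nc2ccc(-c3ccccc3)c(C(F)(F)F)c2)c(=O)c2ccc(CO)cc21`: 27 ug/mL
- compound 3, `Cn1cc(C(=O)Nc2ccc(-c3ccccc3)c(C(F)(F)F)c2)c(=O)c2ccc(CCO)cc21`: 6 ug/mL

Compound 3 stands second highest of the three numbers; its number and that of compound 1 lie within the scatter of each other, while compound 2 stands above it by an amount beyond the scatter. Among the compounds with values here, the one step that can be read from these three compounds, a 4.5-fold lower number from compound 2 to compound 3 (0.65 log units; beyond the scatter), changes the length of a hydroxy-bearing chain. Compound 4, `Cn1cc(C(=O)Nc2ccc(-c3ccccc3)c(C(F)(F)F)c2)c(=O)c2ccc(C(=O)O)cc21`, is not yet measured. It differs from compound 3 in one place: carboxy in place of 2-hydroxyethyl on an aromatic carbon. Within the data shown here, no measured step exchanges such a chain for a carboxy, so the step from compound 2 to compound 3 bears only loosely on this change, and the expectation for compound 4 rests on a small spread of numbers and little precedent. Compound 4 is expected to fall near 40 ug/mL, with a wide range from 6 ug/mL to 300 ug/mL. That estimate means a step of a 6.7-fold higher number from compound 3 to compound 4 (0.82 log units; beyond the scatter), stated as an expectation rather than a measured result.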

Compound 4, solubility: 48 ug/mL
Compound 4: the middle estimate sits 1.2-fold (0.08 log units) below what was measured; low and high end bracket the measured number.
By their numbers in this assay, from the lowest: compounds 1 and 3 (each within the scatter of the next); then compounds 2 and 4 (each within the scatter of the next).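

In this assay the exchange of 2-hydroxyethyl for carboxy on this aromatic carbon gives an 8.0-fold higher number from compound 3 to compound 4 (0.90 log units; beyond the scatter) and so moves the number by more than the scatter. Within the data shown here, until now this position had carried only hydroxy-bearing chains, and carboxy is the first group here with a double bond outside the aromatic rings. Among these compounds, the exchange of hydroxymethyl for carboxy gives a 1.8-fold higher number from compound 2 to compound 4 (0.25 log units; within the scatter) and so cannot separate these two groups, which leaves 2-hydroxyethyl as the one group of the three at this position whose number stands apart from both others.

As far as these compounds go, how an amine or a primary amide on this same aromatic carbon would read in this assay remains open. Nothing at hand accounts for why these groups give the numbers they do.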